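A few compounds are considered here, and "the series" means these few. Any claim that something is new, unique, unknown or untested is made for them only; others in the source may bear on it.

Compound 1 `CC1=NN(c2cccc(Cl)c2)C(=O)C12C=CC(=O)C=C2c1cccc(C)c1` carries a 3-chlorophenyl on the amide-type nitrogen of its core and a 3-methylphenyl on a double-bonded ring carbon. In a functional assay on MDA-MB-231 cells (Homo sapiens) for antiproliferative activity, read by CCK-8 assay, with a stated time of 72 h (on this read-out higher numbers stand for weaker inhibition and lower numbers for stronger inhibition), compound 1 gives 22300 nM, the highest of the two numbers recorded so far. Among the measured compounds shown here, its nearest neighbour is compound 2 `CC1=NN(c2cccc(Cl)c2)C(=O)C12C=CC(=O)C=C2c1ccc(C)cc1`, which in this assay gives 3820 nM; the single measured step, a 5.8-fold lower number from compound 1 to compound 2 (0.77 log units; beyond the scatter), came from 4-methylphenyl in place of 3-methylphenyl on the double-bonded ring carbon and was modest though beyond the scatter.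

Compound 3 `CC1=NN(c2ccc(Br)cc2)C(=O)C12C=CC(=O)C=C2c1cccc(C)c1` differs from compound 1 elsewhere: 4-bromophenyl in place of 3-chlorophenyl on an amide-type nitrogen in a ring. For the measured compounds named here, no measured step touches the aryl group on this ring nitrogen; the one step in hand concerns the other aryl group, so it cannot be carried over, and the effect of exchanging the halogen and shifting it from the 3-position to the 4-position is unknown here. With nothing to push the expectation either way, a step of a 1.4-fold lower number from compound 1 to compound 3 (0.14 log units; within the scatter) in this assay is expected, within the scatter. Compound 3 is therefore estimated to give 16000 nM in this assay, with a range from 5000 nM to 50000 nM.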

Compound 3, half-maximal inhibitory concentration: 2890 nM
Compound 3: middle estimate off by 5.5-fold (0.74 log units), on the high side, outside the stated range (below it).
By their numbers in this assay, from the lowest: compounds 3 and 2 (each within the scatter of the next); then compound 1.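

Among the compounds shown here, the aryl group on the ring nitrogen, which no earlier step had touched, turns out to matter in this assay: a 7.7-fold lower number from compound 1 to compound 3 (0.89 log units; beyond the scatter), a step that is modest but beyond the scatter. Together with the earlier step on the double-bonded ring carbon, a 5.8-fold lower number from compound 1 to compound 2 (0.77 log units; beyond the scatter), this shows that the number of compound 1 responds to a change on either aryl group, and in both steps a substituent at the 4-position of a phenyl replaces one at the 3-position and the number falls, a pattern that rests on these compounds alone and that no compound shown goes against. No measurement given here explains why the number falls on this change at the ring nitrogen.

The compounds shown leave open whether the step belongs to bromine in place of chlorine or to the shift from the 3-position to the 4-position, two changes that 4-chlorophenyl or 3-bromophenyl on the same nitrogen would separate. They also leave open whether a phenyl carrying a non-halogen group, such as methoxy or nitrile, would behave alike, and whether 4-bromophenyl and 4-methylphenyl together in one compound would add up.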